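Cyclobutyl Amide in Place of Difluorocyclohexyl

This account rests on a few compounds, and the source may have more. Where it says the series, first, only, none or still open, it means among the compounds named here.

Compound 1 `O=C(C1CCC(F)(F)CC1)N1CC(c2nc(-c3cccc(Cl)c3)no2)C1` was tested in an assay on HEK293 cells for negative allosteric modulation of metabotropic glutamate receptor 5 (Homo sapiens), read by FLIPR (a lower number here means a stronger inhibitor, a higher number a weaker inhibitor), and gave > 10000 nM, which is a limit of the assay and not a number. Compound 2 `O=C(C1CCC(C(F)(F)F)CC1)N1CC(c2nc(-c3cccc(F)c3)no2)C1` also reached only a limit, > 10000 nM. Compound 3 `Cc1cccc(-c2noc(C3CN(C(=O)C4CCC(F)(F)CC4)C3)n2)c1` sits at a limit as well, > 10000 nM. The one single-point step among these, a step that the two limits leave unreadable from compound 1 to compound 3, cannot be read because both ends are limits; the same holds for every value shown, since (the limit of > 10000 nM in this assay, at which 3 of the 3 values shown sit).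

Compound 4 `O=C(C1CCC1)N1CC(c2nc(-c3cccc(Cl)c3)no2)C1` differs from compound 1 by cyclobutyl in place of 4,4-difluorocyclohexyl on a carbonyl carbon. For the measured compounds named here, no measured step touches the group on the carbonyl carbon, so nothing among the three compounds tells whether a smaller ring there moves potency, and the only step on record is itself unreadable. Compound 4 is therefore expected to behave much like compound 1 and to sit at or near the limit, with an estimated value of 15000 nM and a range from 4000 nM to 60000 nM. The step that this estimate implies, a step that the limit leaves unreadable from compound 1 to compound 4, is expected to be small and most likely not resolvable in this assay.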

Compound 4, half-maximal inhibitory concentration: 1500 nM
For compound 4 the middle estimate is 10-fold (1.00 log units) above the measured one; the measured number lies below the stated range.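

For the compounds shown here, the group on the carbonyl carbon proves to be a place where this assay responds: cyclobutyl in place of 4,4-difluorocyclohexyl gives an at least 6.6-fold lower number from compound 1 to compound 4 (0.82 log units; beyond the scatter), the first step in this set that can be read. Compound 4 is also the only compound shown that gives a number rather than a limit, so it offers the first point from which further changes could be sized: the limit of > 10000 nM in this assay, at which 3 of the 4 values shown sit. Compound 1 sits at a limit, so the step fixes only a minimum size, and the true gap to compound 4 could be larger.

This single change swaps the ring and removes both fluorines at once, so the compounds shown cannot separate the two, and plain cyclohexyl or cyclopentyl on the same carbonyl carbon would be needed to tell them apart. The step from chloro to methyl on the aromatic carbon remains unreadable at the limit, which leaves open whether methyl, or a group such as methoxy, would be tolerated there alongside the cyclobutyl amide of compound 4.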